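This account rests on a few compounds, and the source may have more. Where it says the series, first, only, none or still open, it means among the compounds named here.

Measured so far:
compound 1, `NS(=O)(=O)CC(=O)NCCSc1nonc1/C(=N/O)Nc1cccc(C(F)F)c1`: 17 nM
compound 2, `NS(=O)(=O)CC(=O)NCCSc1nonc1/C(=N/O)Nc1ccc(F)c(C(F)F)c1`: 13 nM

Both compounds were tested in an assay for inhibition of Indoleamine 2,3-dioxygenase 1 (Homo sapiens), read by fluorescence, with a stated time of 24 h; on this read-out higher numbers stand for weaker inhibition and lower numbers for stronger inhibition. Compound 2 gives 13 nM in this assay, and compound 1 gives 17 nM. Among the measured compounds shown here, the only step between them, a 1.3-fold lower number from compound 1 to compound 2 (0.12 log units; within the scatter), comes from a fluoro in place of hydrogen on an aromatic carbon and is within the scatter, so the two numbers cannot be told apart; compound 2 simply sits alongside compound 1.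

Compound 3, `CC1(C(=O)NCCSc2nonc2/C(=N/O)Nc2ccc(F)c(C(F)F)c2)CCN1`, has not been measured. It differs from compound 2 in a different part of the molecule: a group of 5 heavy atoms (4 carbon, 1 nitrogen; one four-membered non-aromatic ring with 1 hetero atom) in place of a group of 5 heavy atoms (1 carbon, 1 nitrogen, 2 oxygen, 1 sulfur; no ring), on a carbonyl carbon. For the measured compounds named here, no measured step touches this position, since the one known step concerns the aromatic ring, so nothing here shows how this assay responds to a change at the carbonyl carbon. With no guide of that kind, the working expectation is that compound 3 stays close to compound 2, with a step of a 1.9-fold higher number from compound 2 to compound 3 (0.28 log units; within the scatter) that may fall within the scatter or somewhat beyond it toward weaker inhibition. Compound 3 is therefore estimated at 25 nM, with a range from 8 nM to 80 nM.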

Compound 3, half-maximal inhibitory concentration: 16 nM
Estimate against measurement, compound 3: 1.6-fold (0.19 log units) above; low and high end bracket the measured number.
By their numbers in this assay, from the lowest: compounds 2, 3 and 1 (each within the scatter of the next).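

Among the compounds shown here, until now the only measured step lay on the aromatic ring, so nothing showed how this assay responds to a change on the carbonyl carbon. Replacing sulfamoylmethyl with a group that has no common name, built on one four-membered non-aromatic ring with 1 hetero atom, gives a 1.2-fold higher number from compound 2 to compound 3 (0.09 log units; within the scatter) and so leaves two numbers that cannot be told apart, even though the entering group has no sulfur, has no double bonds outside aromatic rings and counts 1 hydrogen-bond acceptor instead of 2. At this position, then, two groups of 5 heavy atoms that share little else in their make-up read the same, but nothing measured here explains that match.

This is a single pair, so it does not show whether other groups on the carbonyl carbon would read the same, such as a carboxylic acid, a simple amine, a longer carbon chain or a larger ring like piperidine. It also leaves open whether a smaller group, such as plain methyl, would still give a number in the same range.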